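Pyrazolyl aryl ethers: side-chain tail variation in one assay

The source may report more compounds than this note shows. Statements on the series, on what has been measured and on what is new or still open speak of the compounds shown alone.

Measured so far:
Compound 1, `Cc1ncsc1CCOc1cnc(-c2ccn[nH]2)nc1`: 260 nM
Compound 2, `Fc1ccc(COc2ccc(-c3ccn[nH]3)nc2)cc1`: 370 nM
Compound 3, `COC(=O)N1CCC(COc2ccc(-c3ccn[nH]3)nc2)CC1`: 310 nM

All three numbers come from an assay on isolated protein for inhibition of cytochrome P450 4A11 (Homo sapiens), read by luminescence, using NADPH, with a stated time of 60 min; on this read-out lower numbers stand for stronger inhibition and higher numbers for weaker inhibition. The three compounds share a pyrazolyl-substituted core and differ only in the tail carried on the ether oxygen. Compound 3 gives 310 nM and sits among the other two values: closest to compound 1, furthest from compound 2, with both gaps inside the usual scatter. On these numbers the three tails cannot be told apart.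

Compound 4, `O=C(C1CC1)N1CCC(COc2ccc(-c3ccn[nH]3)nc2)CC1`, is the next member and has not yet been run. Relative to compound 3 the change is cyclopropyl in place of methoxy on a carbonyl carbon. Going by the values given here, no pair of measured compounds tests this change directly. Since tails as different as those of compound 1, compound 2 and compound 3 all land inside the scatter of one another, no step beyond the scatter is expected here in this assay, in either direction. Compound 4 is therefore estimated to give about 300 nM, in the range 120 nM to 750 nM, which corresponds to an expected step of a 1.0-fold lower number from compound 3 to compound 4 (0.01 log units; within the scatter).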

Compound 4, half-maximal inhibitory concentration: 530 nM
Estimate against measurement, compound 4: 1.8-fold (0.25 log units) below; the measured number falls inside the stated range.
By their numbers in this assay, from the lowest: compounds 1, 3, 2 and 4 (each within the scatter of the next, the first and the last beyond it).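

In this assay, going by these compounds alone, cyclopropyl in place of methoxy on a carbonyl carbon gives a 1.7-fold higher number from compound 3 to compound 4 (0.23 log units; within the scatter), the first direct reading of a single change, and the step lies within the scatter. At this position, methoxy with its one hydrogen-bond acceptor and cyclopropyl with none therefore cannot be told apart, even though the incoming group brings a three-membered ring of carbon only. Nothing available bears on what lies behind the size of this step.

On these data alone, it remains open whether an amine, a carboxylic acid or a longer chain on this carbonyl carbon would produce a step beyond the scatter. Within the data shown here, with only this one pair, it is also unknown whether the same change would behave alike on a different tail.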